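Changing the benzyl group on a shared nucleoside core

The compounds below may be only part of what the source reports. "The series", "measured", "known", "first", "only" and "open" are said of these compounds alone.

Three compounds share one core and differ only in the aryl group on a saturated chain carbon bound to a nitrogen on an aromatic ring. Compound 1 `OC[C@H]1O[C@@H](n2cnc3c(NCc4ccc(F)cc4)ncnc32)[C@H](O)[C@@H]1O` carries a 4-fluorophenyl there and, in a functional assay on K562 cells (Homo sapiens) for antiproliferative activity, with a stated time of 72 h (a lower number here means a stronger inhibitor, a higher number a weaker inhibitor), compound 1 gives 2700 nM. Compound 2 `OC[C@H]1O[C@@H](n2cnc3c(NCc4ccc(Cl)cc4Cl)ncnc32)[C@H](O)[C@@H]1O` carries a 2,4-dichlorophenyl instead, and in this assay compound 2 gives 106000 nM, a change described by a 39-fold higher number from compound 1 to compound 2 (1.59 log units; beyond the scatter). Compound 3 `COc1ccc(CNc2ncnc3c2ncn3[C@@H]2O[C@H](CO)[C@@H](O)[C@H]2O)c(OC)c1` carries a 2,4-dimethoxyphenyl. For compound 3 this assay reports only a limit, > 166000 nM. Thus compound 3 stands at the weak end of the three: the step of an at least 61-fold higher number from compound 1 to compound 3 (1.78 log units; beyond the scatter) is large, while the step of an at least 1.5-fold higher number from compound 2 to compound 3 (0.19 log units; that floor lies within the scatter) cannot be sized. Compound 4 `OC[C@H]1O[C@@H](n2cnc3c(NCc4ccccc4OC(F)F)ncnc32)[C@H](O)[C@@H]1O` is not yet measured; it differs from compound 3 by 2-(difluoromethoxy)phenyl in place of 2,4-dimethoxyphenyl on a saturated chain carbon bound to a nitrogen on an aromatic ring. Within the data shown here, no measured step matches this change, and a limit gives no fixed starting point. What the three values show is that the 4-fluorophenyl of compound 1 stands far stronger than either doubly substituted aryl of compound 2 or compound 3. Among the measured compounds shown here, the single substituent of compound 4 is expected to land between those extremes, and the estimated step is an at least 3.3-fold lower number from compound 3 to compound 4 (0.52 log units; beyond the scatter). Compound 4 is therefore estimated at 50000 nM, within 8000 nM to 200000 nM.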

Compound 4, half-maximal inhibitory concentration: > 166000 nM
Compound 4 was reported as a limit (the forecaster's own chance of this, stated with the estimate: 35%); middle value at least 3.3-fold (0.52 log units) away from the limit.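

Swapping in the 2-(difluoromethoxy)phenyl group gives an at least 61-fold higher number from compound 1 to compound 4 (1.78 log units; beyond the scatter), so an aryl group with a single substituent can also sit at the weak end of this series, and the number of substituents alone does not separate the 4-fluorophenyl group from the others at this position. The change from the 2,4-dichlorophenyl group gives an at least 1.5-fold higher number from compound 2 to compound 4 (0.19 log units; that floor lies within the scatter), and that floor fixes no order. Compound 3 and compound 4 both stand at a limit of the assay, so the step between them cannot be read, and neither can any ranking of the two: the limit of > 166000 nM in this assay, at which 2 of the 4 values shown sit.

Among these compounds, the compounds measured so far include none with a plain phenyl or a 4-chlorophenyl group on the same saturated chain carbon. Such compounds would show whether a number like that of compound 1 persists without the fluorine or with a chlorine in its place. Also open, going by these compounds, is whether a group of another kind, such as a pyridine ring or a carboxylic acid on the aryl ring, would bring the number back towards that of compound 1.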